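This account rests on a few compounds, and the source may have more. Where it says the series, first, only, none or still open, it means among the compounds named here.

Of the compounds shown here, two have so far been tested in a functional assay on HCT-116 cells (Homo sapiens) for cytotoxicity, read by MTT assay, with a stated time of 72 h; on this read-out lower numbers stand for stronger inhibition and higher numbers for weaker inhibition. In this test, compound 1 `Nc1ccc(Nc2c(C(=O)NCc3ccc(F)cc3)nc(Br)c3cccnc23)cc1` gives 10000 nM, and compound 2 `N[C@H]1CC[C@H](NC(=O)c2nc(Br)c3cccnc3c2NCc2ccc(F)cc2)CC1` gives 6400 nM. These two numbers lie within the usual scatter of each other, so compound 1 stands level with compound 2 and neither can be ranked ahead of the other.

Compound 3 `O=C(NCc1ccc(F)cc1)c1nc(Br)c2cccnc2c1NCCO` has not yet been measured in this assay. It differs from compound 1 in one place: 2-hydroxyethyl in place of 4-aminophenyl on a nitrogen on an aromatic ring. Put simply, 2-hydroxyethyl sits in place of 4-aminophenyl on a nitrogen on an aromatic ring, so a six-membered aromatic ring of carbon leaves and no ring enters. Among the measured compounds shown here, no measured pair shows what a swap of this kind does here, so any expectation has to remain loose, and the range must be wide. With so little to go on, no change beyond the scatter is expected. The estimated step is a 1.3-fold lower number from compound 1 to compound 3 (0.10 log units; within the scatter), which is expected to stay within the scatter. For compound 3 the estimated value is 8000 nM, with an expected range from 3000 nM to 20000 nM.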

Compound 3, half-maximal inhibitory concentration: > 20000 nM
Compound 3 was reported as a limit; the forecaster's own chance of this, stated with the estimate: 15%; middle value at least 2.5-fold (0.39 log units) from the limit.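

Among the compounds shown here, this is the first swap read at this nitrogen on an aromatic ring: in this assay, putting 2-hydroxyethyl in place of 4-aminophenyl gives an at least 2.0-fold higher number from compound 1 to compound 3 (0.30 log units; that floor lies within the scatter). Compound 3 is reported as a limit, > 20000 nM, and this is not an exact number. Trading the six-membered aromatic ring for a chain with no ring therefore brought no lower number at this position, although the floor of the step lies within the scatter, and the full size of the step stays unread because the reading for compound 3 is only this: the limit of > 20000 nM in this assay, at which 1 of the 3 values shown sits.

On these data alone, with a single swap read at this position, it remains open whether the ring or the amine carried on it counts for more, and a plain phenyl group, which has the ring without the amine, would help to separate the two. As far as these compounds go, it also remains open how a longer chain ending in an amine or a carboxylic acid would behave at this nitrogen on the core of compound 1.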